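Methoxy to methyl(phenyl)amino on the shared core

The source may hold more compounds than are shown below. What is called first, only, known or untested is meant among the compounds shown, and "the series" means these compounds.

Measured so far in a functional assay on HL-60 cells (Homo sapiens) for inhibition, with a stated time of 72 h; a higher number here means a weaker inhibitor, a lower number a stronger inhibitor:
Compound 1, `OC[C@H]1O[C@@H](n2cnc3c(COc4ccccn4)ncnc32)[C@H](O)[C@@H]1O`: compound 1 gives 12000 nM.
Compound 2, `COCc1ncnc2c1ncn2[C@@H]1O[C@H](CO)[C@@H](O)[C@H]1O`: compound 2 gives 13000 nM.

Compound 2 stands highest of the two numbers, but the step of a 1.1-fold higher number from compound 1 to compound 2 (0.03 log units; within the scatter) is within the scatter, so compound 1 and compound 2 are not separated. Compound 3, `CN(Cc1ncnc2c1ncn2[C@@H]1O[C@H](CO)[C@@H](O)[C@H]1O)c1ccccc1`, differs from compound 2 by methyl(phenyl)amino in place of methoxy on a saturated chain carbon bound to an aromatic carbon. For the measured compounds named here, only the step from compound 1 to compound 2 bears on this change, and it shows that altering the group at this place left the number essentially unchanged. The expected step is therefore a 1.2-fold lower number from compound 2 to compound 3 (0.07 log units; within the scatter), with no direction claimed beyond the scatter. Compound 3 is estimated at 11000 nM, in the range 3500 nM to 35000 nM.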

Compound 3, half-maximal inhibitory concentration: 4000 nM
Beside the measured number, compound 3's estimate is 2.8-fold (0.44 log units) above it, and the stated range covers the measured number.
By their numbers in this assay, from the lowest: compound 3; then compounds 1 and 2 (each within the scatter of the next).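

In this assay, the nitrogen-linked group separates itself from both oxygen-linked groups at this place, on a saturated chain carbon bound to an aromatic carbon: the steps are a 3.3-fold lower number from compound 2 to compound 3 (0.51 log units; beyond the scatter) and a 3.0-fold lower number from compound 1 to compound 3 (0.48 log units; beyond the scatter), both modest. For the compounds shown here, compound 1 and compound 2 could not be separated, so this is the first change here that reads beyond the scatter. Nothing available accounts for these steps.

Still open, from the compounds shown here alone, is whether the phenyl ring or the amine nitrogen carries the step. Dimethylamino and anilino groups at this place would separate the two.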